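Compound 2 to compound 3: a change of aryl group

The source may report more compounds than this note shows. Statements on the series, on what has been measured and on what is new or still open speak of the compounds shown alone.

Compound 1 `Cc1ccc(S/C(=C/c2sccc2C)C(=O)c2ccc(Br)cc2)cc1` gives 50000 nM
Compound 2 `Cc1ccc(S/C(=C/c2ccc(F)c(C)c2)C(=O)c2ccc(Br)cc2)cc1` gives 25000 nM

In a functional assay on DU-145 cells (Homo sapiens) for inhibition, read by trypan blue exclusion, with a stated time of 96 h (on this read-out lower numbers stand for stronger inhibition of growth and higher numbers for weaker inhibition of growth), compound 2 gives 25000 nM and compound 1 gives 50000 nM, so the two stand within the scatter of each other. Compound 3 `Cc1ccc(S/C(=C/c2ccc(Cl)cc2)C(=O)c2ccc(Br)cc2)cc1` has not yet been measured, and its change from compound 2 is this: 4-chlorophenyl in place of 4-fluoro-3-methylphenyl on a double-bonded chain carbon bound to a double-bonded chain carbon. Going by the values given here, because of a 2.0-fold lower number from compound 1 to compound 2 (0.30 log units; within the scatter), the only measured step at this place and one within the scatter, no step beyond the scatter is expected in this assay. The expected step is a 1.1-fold lower number from compound 2 to compound 3 (0.06 log units; within the scatter). For compound 3 the estimated value is 22000 nM, with an expected range from 9000 nM to 50000 nM.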

Compound 3, concentration for 50% growth inhibition: 10000 nM
Beside the measured number, compound 3's estimate is 2.2-fold (0.34 log units) above it; measured number inside the range.
By their numbers in this assay, from the lowest: compound 3; then compounds 2 and 1 (each within the scatter of the next).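

In this assay this place on a double-bonded chain carbon bound to a double-bonded chain carbon now shows a step beyond the scatter: 4-chlorophenyl in place of 4-fluoro-3-methylphenyl gives a 2.5-fold lower number from compound 2 to compound 3 (0.40 log units; beyond the scatter) and 4-chlorophenyl in place of 3-methylthiophen-2-yl gives a 5.0-fold lower number from compound 1 to compound 3 (0.70 log units; beyond the scatter). Both steps are modest, yet they show that the group here can shift growth inhibition, with compound 3 the strongest of the three. Nothing available explains the gain.

The compounds shown leave open whether the chlorine itself matters, and what an amine or a carboxylic acid on the phenyl ring would give at this place.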